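Swapping the amine on the chain of compound 2

A few compounds are considered here, and "the series" means these few. Any claim that something is new, unique, unknown or untested is made for them only; others in the source may bear on it.

compound 1 `CN(C)CCCNc1nc(-c2[nH]c3ccccc3c2C=O)nc2ccccc12` gives 2.18 h
compound 2 `CCN(CC)CCCCNc1nc(-c2[nH]c3ccc(OC)cc3c2C=O)nc2ccccc12` gives 4.28 h
compound 3 `COc1ccc2[nH]c(-c3nc(NCCN4CCCC4)c4ccccc4n3)c(C=O)c2c1` gives 1.75 h

In an ADME assay on microsomes from liver (Rattus norvegicus, strain Sprague-Dawley) for metabolic stability, read by LC-MS, using NADPH, with a stated time of 60 min, tested at 10 mM (on this read-out lower numbers stand for a shorter-lived compound and higher numbers for a longer-lived compound), compound 2 gives 4.28 h and stands within the scatter of compound 1 and beyond the scatter of compound 3. Compound 4 `COc1ccc2[nH]c(-c3nc(NCCCCN4CCCC4)c4ccccc4n3)c(C=O)c2c1` has not yet been measured. In it, pyrrolidin-1-yl takes the place of diethylamino on a saturated chain carbon, four bonds along the chain from a nitrogen on an aromatic ring pyrrolidin-1-yl in place of diethylamino on a saturated chain carbon, four bonds along the chain from a nitrogen on an aromatic ring and the rest of compound 2 stays as it is.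

Going by the values given here, one measured step bears on this change. It puts pyrrolidin-1-yl in place of 2-(diethylamino)ethyl, so the chain length changes as well, whereas compound 4 keeps the chain of compound 2. Among the compounds with values here, no measured step shows the amine swap alone. Within the data shown here, with a 2.4-fold lower number from compound 2 to compound 3 (0.39 log units; beyond the scatter) as the only guide, a smaller step in the same direction is expected, probably within the scatter. The estimated step is a 1.3-fold lower number from compound 2 to compound 4 (0.11 log units; within the scatter) in this assay terms. The estimate for compound 4 is 3.3 h with an expected range from 1.9 h to 5.6 h.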

Compound 4, half-life: 3.12 h
Compound 4: the middle estimate sits 1.1-fold (0.02 log units) above what was measured; low and high end bracket the measured number.
By their numbers in this assay, from the lowest: compounds 3, 1, 4 and 2 (each within the scatter of the next, the first and the last beyond it).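

With the chain held fixed, the amine swap alone gives a 1.4-fold lower number from compound 2 to compound 4 (0.14 log units; within the scatter) in this assay, so this assay does not tell pyrrolidin-1-yl from diethylamino at this place. With pyrrolidin-1-yl held fixed, the chain change alone gives a 1.8-fold higher number from compound 3 to compound 4 (0.25 log units; within the scatter), which means that the larger 2.4-fold lower number from compound 2 to compound 3 (0.39 log units; beyond the scatter), where both changes are made together, now separates into two parts, neither of which lies beyond the scatter on its own. Nothing in the data at hand accounts for these numbers.

From the compounds shown here alone, whether a piperidin-1-yl or morpholin-4-yl group on the same chain would stay this close to diethylamino remains open. Going by these compounds, it is also open whether diethylamino and pyrrolidin-1-yl would stay this close on the shorter chain of compound 3 .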